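The compounds below may be only part of what the source reports. "The series", "measured", "known", "first", "only" and "open" are said of these compounds alone.

The measured compounds:
Compound 1 `Cc1ccc(-c2nnc(Nc3csc(-c4ccccc4)c3)s2)cc1` gives 4000 nM in a functional assay on B16-F10 cells (Mus musculus) for inhibition, read by colorimetric assay and MTT assay, with a stated time of 72 h; on this read-out lower numbers stand for stronger inhibition and higher numbers for weaker inhibition.
Compound 2 `COc1ccc(-c2nnc(Nc3csc(-c4ccccc4)c3)s2)cc1` gives 6000 nM in this assay.
Compound 3 `COc1ccc(-c2nnc(Nc3csc(-c4ccc(C)cc4)c3)s2)cc1` gives "not determined" (no result reported) in this assay, that is no result.

For the measured compounds named here, compound 2 stands with the higher of the two numbers in this assay; its nearest neighbour is compound 1, and the single measured step, a 1.5-fold higher number from compound 1 to compound 2 (0.18 log units; within the scatter), lies within the scatter, so the two compounds cannot be ordered against each other. Compound 3 contributes no number and so adds nothing to the comparison.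

Compound 4 `Oc1ccc(-c2nnc(Nc3csc(-c4ccccc4)c3)s2)cc1` differs from compound 2 by hydrogen in place of methyl on an oxygen on an aromatic ring, read one bond further out as methoxy to hydroxy. Going by the values given here, no measured step bears directly on this change. Among the compounds with values here, the only step available, a 1.5-fold higher number from compound 1 to compound 2 (0.18 log units; within the scatter), exchanges methyl for methoxy on an aromatic carbon and stays within the scatter, which gives no sign that a small change at this part of the molecule moves the number far. Going by these compounds, nothing measured here contains a hydroxy group, so the change is untested. Compound 4 is therefore expected to give a number close to that of compound 2. The expected step is no change at the digits printed from compound 2 to compound 4 (within the scatter), nothing beyond the scatter. The estimate for compound 4 in this assay is 6000 nM, with a range from 2500 nM to 14000 nM.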

Compound 4, half-maximal inhibitory concentration: 8000 nM
Estimate against measurement, compound 4: 1.3-fold (0.12 log units) below; low and high end bracket the measured number.
By their numbers in this assay, from the lowest: compounds 1, 2 and 4 (each within the scatter of the next).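

Compound 4 alone among the compounds shown carries a hydroxy group at this position, and in this assay the exchange of methoxy for hydroxy, a 1.3-fold higher number from compound 2 to compound 4 (0.12 log units; within the scatter), gives a difference that cannot be separated from the scatter. The exchange of methyl for hydroxy on the same aromatic carbon, a 2.0-fold higher number from compound 1 to compound 4 (0.30 log units; within the scatter), is also printed as within the scatter, so methyl, methoxy and hydroxy at this place cannot be ordered against one another, a statement that holds for these three compounds only. Nothing at hand offers an explanation for how close these three numbers lie.

Going by these compounds, whether the numbers stay this close with a group of another kind at this place, such as an amine, a carboxylic acid or a longer alkoxy chain, remains open. Changes elsewhere in the molecule also remain open, since compound 3, which differs from compound 2 away from this position, has no result to compare.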